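Removing One Chloro Group on Two Related Cores

The source may hold more compounds than are shown below. What is called first, only, known or untested is meant among the compounds shown, and "the series" means these compounds.

Three compounds were tested in a functional assay on T47D cells (Homo sapiens) for cytotoxicity, read by sulforhodamine B assay, with a stated time of 48 h; a lower number here means that less compound is tolerated, a higher number that more compound is tolerated. Compound 1 `ClCc1ccc(Cn2cnc3nc(Cl)nc(Cl)c32)cc1` sits at a limit of that assay rather than at a number: in this assay compound 1 gives > 100000 nM. Compound 3 `ClCc1ccccc1Cn1cnc2nc(Cl)nc(Cl)c21` likewise reaches a limit, and in this assay compound 3 gives > 100000 nM. Compound 2 `ClCc1ccccc1Cn1cnc2ncnc(Cl)c21` gives a number instead: in this assay compound 2 gives 4260 nM.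

The structural change from compound 3 to compound 2 is hydrogen in place of chloro on an aromatic carbon. The step it made is an at least 23-fold lower number from compound 3 to compound 2 (1.37 log units; beyond the scatter). Its size can only be stated as a bound because compound 3 sits at the limit of > 100000 nM in this assay, at which 2 of the 3 values shown sit.

Compound 4 `ClCc1ccc(Cn2cnc3ncnc(Cl)c32)cc1` has not yet been measured. It differs from compound 1 by hydrogen in place of chloro on an aromatic carbon, and this is the same change as that from compound 3 to compound 2, at a place described in the same words. How the core of compound 1 differs from the core of compound 3 is not broken down here.

From compound 1 to compound 4 a step of the same kind and order is expected in this assay, an at least 20-fold lower number from compound 1 to compound 4 (1.30 log units; beyond the scatter), resting on the earlier step of an at least 23-fold lower number from compound 3 to compound 2 (1.37 log units; beyond the scatter) and on compound 1 sitting at a limit, > 100000 nM. Compound 4 is therefore estimated to give 5000 nM in this assay. The estimate for compound 4 carries a likely range from 1500 nM to 30000 nM.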

Compound 4, concentration lethal to 50% of the cells: 6300 nM
Compound 4: middle estimate off by 1.3-fold (0.10 log units), on the low side; the measured number falls inside the stated range.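

In this assay, replacing the chloro group between two ring nitrogen atoms with hydrogen gave an at least 15-fold lower number from compound 1 to compound 4 (1.20 log units; beyond the scatter), so on the core of compound 1, as on the core of compound 3, the change lowers the number by a margin beyond the scatter. Set side by side, the two steps on the two cores read: the same change on two cores in this assay, an at least 23-fold lower number (1.37 log units; beyond the scatter) from compound 3 to compound 2 and an at least 15-fold lower number (1.20 log units; beyond the scatter) from compound 1 to compound 4; the limit leaves it open whether they differ. The pair therefore shows that the direction of the change carries from one core to the other, but it does not show that the change has the same size on both, and neither step has an exact size, as compound 1 and compound 3 each sit at a limit and not at a number: the limit of > 100000 nM in this assay, at which 2 of the 4 values shown sit.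

The compounds shown leave open what happens when something other than hydrogen takes the place of this chloro group, such as an amine or a methoxy group, and whether such a group would also bring the number within the measurable range on both cores. They also leave open what the other chloro group and the chloromethyl group contribute, as both stay unchanged in every step shown, and a hydroxymethyl group in place of the chloromethyl group would be one way to read this.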